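The source may report more compounds than this note shows. Statements on the series, on what has been measured and on what is new or still open speak of the compounds shown alone.

Three compounds of this series have numbers in an ADME assay on Caco-2 cells (Homo sapiens) for permeability, read by LC-MS, in the apical to basolateral direction, with a stated time of 60 min, at pH 6.5; a higher number here means that the compound crosses the layer faster, a lower number that the compound crosses the layer more slowly. Compound 1, `CC(C)(C)[C@@H](O)C(=O)N1[C@@H]2C[C@@H]2C[C@H]1C(=O)NCc1cc(Cl)ccc1-n1cnnn1`, gives 34 10^-6 cm/s. Compound 2, `CC(C)(C)[C@@H](O)C(=O)N1Cc2ccccc2[C@H]1C(=O)NCc1cc(Cl)ccc1-n1nnnn1`, gives 9 10^-6 cm/s. Compound 3, `CCCC[C@@H](O)C(=O)N1N=CC[C@H]1C(=O)NCc1cc(Cl)ccc1-n1cnnn1`, gives 9.8 10^-6 cm/s, the second highest of the three; against compound 2 the two values lie within the scatter, so no order is read between them, while compound 1 sits higher by a gap beyond the scatter.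

The step under review leads from compound 3 to compound 4, `COC(C)(C)[C@@H](O)C(=O)N1N=CC[C@H]1C(=O)NCc1cc(Cl)ccc1-n1cnnn1`, not yet measured in this assay. The change is 1-methoxy-1-methylethyl in place of butyl on a saturated chain carbon bound to a carbonyl carbon and an oxygen on a saturated carbon. The substituent that enters brings one hydrogen-bond acceptor that the butyl group did not carry, on a saturated chain carbon bound to a carbonyl carbon and an oxygen on a saturated carbon. Among the measured compounds shown here, no measured pair isolates such a change, so the expectation rests on compound 3 alone.

The expected step from compound 3 to compound 4 in this assay is a 1.4-fold lower number from compound 3 to compound 4 (0.15 log units; within the scatter), a small decrease that is not expected to exceed the scatter. Compound 4 is therefore estimated at 7 10^-6 cm/s, with a range from 3.5 10^-6 cm/s to 14 10^-6 cm/s.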

Compound 4, apparent permeability: 1.7 10^-6 cm/s
The estimate for compound 4 lay 4.1-fold (0.61 log units) above the measured number; measured number outside the range, below it.
By their numbers in this assay, from the lowest: compound 4; then compounds 2 and 3 (each within the scatter of the next); then compound 1.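

Among the compounds shown here, on a saturated chain carbon bound to a carbonyl carbon and an oxygen on a saturated carbon, 1-methoxy-1-methylethyl in place of butyl gives a 5.8-fold lower number from compound 3 to compound 4 (0.76 log units; beyond the scatter) in this assay, the first step that isolates a change at this place. The number at this position therefore responds to the group it carries, and this change moves it beyond the scatter. Nothing measured here explains the size of the step.

Open, on these data alone, is whether the step follows the ether oxygen, the branching of the chain, or both together; a 3-methoxypropyl chain at this place on the core of compound 3 would keep the oxygen without the branching. Also open, as far as these compounds go, is whether the same change gives a step of similar size on the cores of compound 1 and compound 2.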